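The source may report more compounds than this note shows. Statements on the series, on what has been measured and on what is new or still open speak of the compounds shown alone.

Measured compounds:
compound 1 `CCN1CCN(Cc2ccc(NC(=O)c3ccc(C)c(C#Cc4ccc(NC(C)=O)nc4)c3)cc2C(F)(F)F)CC1`: 2050 nM
compound 2 `CCN1CCN(Cc2ccc(NC(=O)c3ccc(C)c(C#Cc4cnccn4)c3)cc2C(F)(F)F)CC1`: 2490 nM
compound 3 `CCN1CCN(Cc2ccc(NC(=O)c3ccc(C)c(C#Cc4cnc(N)cn4)c3)cc2C(F)(F)F)CC1`: 860 nM

In a functional assay on BaF3 cells (Mus musculus) for antiproliferative activity (on this read-out higher numbers stand for an effect only at larger amounts of compound and lower numbers for an effect already at smaller amounts), compound 1 stands second highest of the three numbers; compound 2 lies within the scatter of it, compound 3 below it. Compound 4 `CCN1CCN(Cc2ccc(NC(=O)c3ccc(C)c(C#Cc4cnc5nccnc5c4)c3)cc2C(F)(F)F)CC1` differs from compound 1 in one place: a group of 10 heavy atoms (7 carbon, 3 nitrogen; one six-membered aromatic ring with 1 hetero atom, one six-membered aromatic ring with 2 hetero atoms) in place of a group of 10 heavy atoms (7 carbon, 2 nitrogen, 1 oxygen; one six-membered aromatic ring with 1 hetero atom), on a triple-bonded carbon. The nearest measured step is a 1.2-fold higher number from compound 1 to compound 2 (0.08 log units; within the scatter), where exchanging the same group for pyrazin-2-yl changed nothing beyond the scatter. The step of a 2.9-fold lower number from compound 2 to compound 3 (0.46 log units; beyond the scatter) shows that an amino group gives a modest gain, but the entering group of compound 4 carries no donor. For compound 4 a step within the scatter is therefore expected, a 1.1-fold lower number from compound 1 to compound 4 (0.06 log units; within the scatter). Compound 4 is estimated at 1800 nM, range 700 nM to 4500 nM.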

Compound 4, half-maximal effective concentration: 3320 nM
For compound 4 the middle estimate is 1.8-fold (0.27 log units) below the measured one; the measured number falls inside the stated range.
By their numbers in this assay, from the lowest: compound 3; then compounds 1, 2 and 4 (each within the scatter of the next).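

In this assay, the larger group with two six-membered aromatic rings on the triple-bonded carbon stays within the scatter of both earlier groups: a 1.3-fold higher number from compound 2 to compound 4 (0.12 log units; within the scatter) and a 1.6-fold higher number from compound 1 to compound 4 (0.21 log units; within the scatter). Against 5-aminopyrazin-2-yl the picture differs, with a 3.9-fold higher number from compound 3 to compound 4 (0.59 log units; beyond the scatter), so among these compounds only compound 3 stands apart. Nothing available explains these differences. As far as these compounds go, whether an amino group added to the entering group of compound 4 would give a gain like that on pyrazin-2-yl stays open, as does the effect of a carboxylic acid there.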